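The source may report more compounds than this note shows. Statements on the series, on what has been measured and on what is new or still open speak of the compounds shown alone.

For the measured compounds named here, compound 2 `CN(c1ccc2[nH]c(-c3n[nH]c4ccccc34)cc2n1)S(=O)(=O)c1ccccc1` gives 2400 nM in a functional assay on KB cells (Homo sapiens) for antiproliferative activity, read by MTT assay, with a stated time of 72 h (a lower number here means a stronger inhibitor, a higher number a weaker inhibitor), the lower of the two numbers measured so far; compound 1 `COc1ccc(C(=O)N(C)c2ccc3[nH]c(-c4n[nH]c5ccccc45)cc3n2)cc1` gives 12900 nM in this assay. Going by the values given here, the only measured step, a 5.4-fold lower number from compound 1 to compound 2 (0.73 log units; beyond the scatter), changes the group on the ring nitrogen, not the phenyl ring itself. Compound 3 `CN(c1ccc2[nH]c(-c3n[nH]c4ccccc34)cc2n1)S(=O)(=O)c1ccc(Br)cc1` differs from compound 2 by bromo in place of hydrogen on an aromatic carbon. Among the compounds with values here, no measured step speaks to this change, so no shift beyond the scatter is expected. Compound 3 is therefore expected to give 1800 nM in this assay, within 600 nM to 6000 nM. That corresponds to an expected step of a 1.3-fold lower number from compound 2 to compound 3 (0.12 log units; within the scatter).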

Compound 3, half-maximal inhibitory concentration: 7150 nM
Estimate against measurement, compound 3: 4.0-fold (0.60 log units) below, outside the stated range (above it).
By their numbers in this assay, from the lowest: compound 2; then compounds 3 and 1 (each within the scatter of the next).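

In this assay the aromatic carbon para to a large group proves sensitive to substitution, since bromo in place of hydrogen gives a 3.0-fold higher number from compound 2 to compound 3 (0.47 log units; beyond the scatter) on the phenylsulfonyl series. This single atom removes the separation from the carbonyl-linked compound, leaving a 1.8-fold lower number from compound 1 to compound 3 (0.26 log units; within the scatter) as the remaining step. Nothing measured here explains the effect of bromo.

Only hydrogen and bromo are shown at this carbon. Going by these compounds, whether fluoro, methoxy or an amine there would behave like bromo or like hydrogen remains open.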